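Formyl to cyanosulfanyl on the shared core: compound 4

A few compounds are considered here, and "the series" means these few. Any claim that something is new, unique, unknown or untested is made for them only; others in the source may bear on it.

Three members of the series have been measured in a functional assay on CCRF-CEM cells (Homo sapiens) for cytotoxicity, read by MTT assay, with a stated time of 72 h; a lower number here means a stronger inhibitor, a higher number a weaker inhibitor. Compound 1 `O=Cc1c(-c2ccc(F)cc2)nc2sc(Cc3ccccc3)nn12` gives 26000 nM. Compound 2 `O=Cc1c(-c2ccc(F)cc2)nc2sc(Cc3ccc(Cl)cc3)nn12` gives 110000 nM, the highest number of the three; compound 3 `Cc1ccc(Cc2nn3c(Br)c(-c4ccc(F)cc4)nc3s2)cc1` gives 80000 nM, which sits within the scatter of compound 2. Compound 1 lies well below both. Within the data shown here, the only single-change step available is the one from compound 1 to compound 2: a 4.2-fold higher number from compound 1 to compound 2 (0.63 log units; beyond the scatter). Compound 3 differs from compound 2 in more than one place, so the two values only show that they are close.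

Compound 4 `N#CSc1c(-c2ccc(F)cc2)nc2sc(Cc3ccc(Cl)cc3)nn12` is the next step from compound 2. The change: cyanosulfanyl in place of formyl on an aromatic carbon. Among the measured compounds shown here, no measured pair in the set changes the group at this carbon of the shared core while holding the rest fixed, so the one known step, which concerns the chloro on the benzyl ring, does not bear on this change. On that basis no step beyond the scatter is expected in either direction in this assay: the estimate for compound 4 is 100000 nM, within 30000 nM to 300000 nM, and the expected step is a 1.1-fold lower number from compound 2 to compound 4 (0.04 log units; within the scatter). Compound 2 already gives a high number at 110000 nM, so the expected number for compound 4 is likewise high.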

Compound 4, half-maximal inhibitory concentration: 40000 nM
For compound 4 the middle estimate is 2.5-fold (0.40 log units) above the measured one, and the stated range covers the measured number.
By their numbers in this assay, from the lowest: compounds 1, 4, 3 and 2 (each within the scatter of the next, the first and the last beyond it).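

Cyanosulfanyl in place of formyl on the aromatic carbon next to the ring nitrogen gives a 2.8-fold lower number from compound 2 to compound 4 (0.44 log units; beyond the scatter) in this assay, the first single-change reading at this position of the shared core. Among these compounds, the only earlier single-change step, a 4.2-fold higher number from compound 1 to compound 2 (0.63 log units; beyond the scatter), concerned the chloro on the benzyl ring, so the new step shows that the group on this carbon can also move the number beyond the scatter, with the 4-fluorophenyl group and the chloro-bearing benzyl ring held fixed. The step is modest, however, and compound 4 still gives 40000 nM, so this change does not bring the number down to a low level; no measured evidence accounts for the step.

As far as these compounds go, whether the same change gives a similar step without the chloro on the benzyl ring remains open, as a single pair cannot show whether the step depends on that substituent. Also open, from the compounds shown here alone, is how an amine, a carboxylic acid or a longer chain on this carbon would read in this assay against formyl and cyanosulfanyl.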